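Replacing the 3-amino-2-hydroxypropyl group on sulfur in compound 3

The source may report more compounds than this note shows. Statements on the series, on what has been measured and on what is new or still open speak of the compounds shown alone.

compound 1 `CC(C)c1n[nH]c2c(NCc3ccc(-c4ccccn4)cc3)nc(SCCO)nc12` gives 48 nM
compound 2 `CC(C)c1n[nH]c2c(NCc3ccc(-c4ccccn4)cc3)nc(SCC(O)C(F)(F)F)nc12` gives 690 nM
compound 3 `CC(C)c1n[nH]c2c(NCc3ccc(-c4ccccn4)cc3)nc(SCC(O)CN)nc12` gives 55 nM

All three values come from a functional assay on HT cells (Homo sapiens) for antiproliferative activity, read by fluorescence, with a stated time of 72 h (a lower number here means a stronger inhibitor of growth, a higher number a weaker inhibitor of growth), and the compounds share one core. Compound 3 sits level with compound 1, the step between them staying within the scatter (a 1.1-fold higher number from compound 1 to compound 3 (0.06 log units; within the scatter)). Compound 2 lies well apart from it (a 13-fold lower number from compound 2 to compound 3 (1.10 log units; beyond the scatter)).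

The next compound is compound 4 `CC(C)c1n[nH]c2c(NCc3ccc(-c4ccccn4)cc3)nc(SC(C)C(C)O)nc12`, which carries 2-hydroxy-1-methylpropyl in place of 3-amino-2-hydroxypropyl on a sulfur. Among the compounds with values here, none of the measured compounds carries this new group, so no measured step matches the change directly. Within the data shown here, two steps bear on it indirectly. Compound 1 also lacks the amino group and still matches compound 3 (a 1.1-fold higher number from compound 1 to compound 3 (0.06 log units; within the scatter)), so losing that group alone is not expected to cost much. Compound 2 shows that a new group on this chain can cost a great deal (a 14-fold higher number from compound 1 to compound 2 (1.16 log units; beyond the scatter)). A small rise in this assay is therefore expected, with a large one not ruled out. The expected change is modest and may not exceed the scatter (a 1.7-fold higher number from compound 3 to compound 4 (0.24 log units; within the scatter)). For compound 4 the estimated value is 95 nM (expected range 30 nM to 300 nM).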

Compound 4, concentration for 50% growth inhibition: 190 nM
For compound 4 the middle estimate is 2.0-fold (0.30 log units) below the measured one, within the range that was stated.
By their numbers in this assay, from the lowest: compounds 1 and 3 (each within the scatter of the next); then compound 4; then compound 2.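

In this assay, the loss of the amino group is not enough to account for the change on this sulfur: compound 1 also lacks that group and stays level with compound 3, yet 2-hydroxy-1-methylpropyl gives a step beyond the scatter against both, with a 3.5-fold higher number from compound 3 to compound 4 (0.54 log units; beyond the scatter) and a 4.0-fold higher number from compound 1 to compound 4 (0.60 log units; beyond the scatter). The result therefore shows that a chain that keeps its hydroxy group and carries no fluorine can still lose ground, although this group gives a better value than 3,3,3-trifluoro-2-hydroxypropyl, with a 3.6-fold lower number from compound 2 to compound 4 (0.56 log units; beyond the scatter). Nothing measured here gives a reason for these differences.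

The compounds shown leave open whether the step from 2-hydroxyethyl to 2-hydroxy-1-methylpropyl rests on the 1-methyl branch alone or on the further methyl group, a question that 2-hydroxy-1-methylethyl and 2-hydroxypropyl on the same sulfur would separate. They also leave open how a carboxylic acid or a longer chain such as 4-hydroxybutyl would fare at this sulfur in this assay.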